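Chloro in Place of Hydrogen on the Anilide Ring

The source may report more compounds than this note shows. Statements on the series, on what has been measured and on what is new or still open speak of the compounds shown alone.

Measured compounds:
compound 1, `Cc1noc(C)c1-c1cnc(N)c(Oc2ccc(C(=O)Nc3ccccc3Cl)cc2)n1`: > 100000 nM
compound 2, `Cn1cc(-c2cnc(N)c(Oc3ccc(C(=O)Nc4ccccc4)cc3)n2)cn1`: 9210 nM

Compound 1 is recorded in a functional assay on LoVo cells (Homo sapiens) for inhibition, read by MTT assay, with a stated time of 72 h (a higher number here means a weaker inhibitor, a lower number a stronger inhibitor), only as a limit, > 100000 nM, not as a number. Compound 2 gives 9210 nM in this assay and is thus the only compound with a numeric value among the two shown; the other value sits at the limit of > 100000 nM in this assay, at which 1 of the 2 values shown sits. Compound 3, `Cn1cc(-c2cnc(N)c(Oc3ccc(C(=O)Nc4ccccc4Cl)cc3)n2)cn1`, has not yet been measured. It differs from compound 2 by chloro in place of hydrogen on an aromatic carbon, placed on an aromatic carbon of a six-membered aromatic ring of carbon only, ortho to a large group. Among the compounds with values here, no step between measured compounds exists to calibrate this change, and compound 1, which carries a chloro group but also other differences, offers only a limit. Compound 3 is therefore expected to be somewhat weaker than compound 2, the step of a 2.0-fold higher number from compound 2 to compound 3 (0.29 log units; within the scatter) possibly exceeding the scatter. The estimate for compound 3 is 18000 nM, within 4000 nM to 80000 nM.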

Compound 3, half-maximal inhibitory concentration: 41400 nM
Beside the measured number, compound 3's estimate is 2.3-fold (0.36 log units) below it, and the stated range covers the measured number.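

With the 1-methyl-1H-pyrazol-4-yl group held constant, chloro in place of hydrogen now has a step of its own in this assay: a 4.5-fold higher number from compound 2 to compound 3 (0.65 log units; beyond the scatter), so this change, on an aromatic carbon ortho to a large group, weakens inhibition beyond the scatter. With the chloro group held constant, 1-methyl-1H-pyrazol-4-yl in place of 3,5-dimethyl-1,2-oxazol-4-yl gives an at least 2.4-fold lower number from compound 1 to compound 3 (0.38 log units; beyond the scatter). That step is only a bound, because compound 1 is recorded as a limit and not as a number: the limit of > 100000 nM in this assay, at which 1 of the 3 values shown sits.

The compounds shown leave open whether a fluoro, methyl or methoxy group at this place would bring the same step as chloro. They also leave open whether chloro on another carbon of this ring would weaken inhibition, and how large the full step from the 3,5-dimethyl-1,2-oxazol-4-yl group is.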